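This account rests on a few compounds, and the source may have more. Where it says the series, first, only, none or still open, it means among the compounds named here.

Working notes on the series. Among the compounds with values here, compound 1 `O=C1C(Nc2ccccc2F)=CC(=O)c2c1nc1n2[C@H]2OC[C@@H](O)[C@H]2OC1` and compound 2 `Cc1ccc(NC2=CC(=O)c3c(nc4n3[C@H]3OC[C@@H](O)[C@H]3OC4)C2=O)cc1C` share one core; in a functional assay on MCF7 cells (Homo sapiens) for inhibition, read by sulforhodamine B assay (a lower number here means a stronger inhibitor, a higher number a weaker inhibitor), compound 2 gives 4950 nM, the only number recorded so far. In this assay compound 1 gives > 4000 nM, which is a limit and not a number. Within the data shown here, the one step between them, a step that the limit leaves unreadable from compound 1 to compound 2, is therefore not readable, since (the limit of > 4000 nM in this assay, at which 1 of the 2 values shown sits). Compound 2 thus stands alone as the sole measured point. Compound 3 `O=C1C(N2CCCCC2)=CC(=O)c2c1nc1n2[C@H]2OC[C@@H](O)[C@H]2OC1` is the next case: piperidin-1-yl in place of (3,4-dimethylphenyl)amino on a double-bonded ring carbon. Among the measured compounds shown here, no measured step bears on an exchange of this kind, so the direction and size of the step in this assay cannot be taken from the series; the one reference, compound 2, sits in the weak range, and the expected step of a 1.4-fold higher number from compound 2 to compound 3 (0.15 log units; within the scatter) is set near zero with wide spread. Compound 3 is estimated at 7000 nM, expected within 1500 nM to 30000 nM.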

Compound 3, half-maximal inhibitory concentration: > 8000 nM
Compound 3 gave a limit, no number; the forecaster's own chance of this, stated with the estimate: 55%; at least 1.1-fold (0.05 log units) between middle value and limit.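

In this assay compound 3 gives > 8000 nM, which is a limit and not a number: the limit of > 8000 nM in this assay, at which 1 of the 3 values shown sits.

Within the data shown here, the exchange of (3,4-dimethylphenyl)amino for piperidin-1-yl on the double-bonded ring carbon gives the first readable step, an at least 1.6-fold higher number from compound 2 to compound 3 (0.20 log units; that floor lies within the scatter), so it shows no gain in inhibition, though its size remains open. Among these compounds, the steps that involve compound 1 cannot be read, which leaves compound 2 as the only measured number.

The exchange removes the aromatic ring and the hydrogen-bond donor together, and the compounds shown do not separate the two. As far as these compounds go, a cyclohexylamino group on the same ring carbon, which pairs a non-aromatic ring with an amine hydrogen, would part them, while the true value of compound 3 stays unknown.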